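This account rests on a few compounds, and the source may have more. Where it says the series, first, only, none or still open, it means among the compounds named here.

Compound 1 `C[Se]c1nc(N)c2cccnc2n1` and compound 2 `CCCCC[Se]c1nc([Se]CCCCC)c2cccnc2n1` share one core. In an ADME assay on 184B5 cells (Homo sapiens) for cytotoxicity, read by MTT assay, with a stated time of 72 h (a lower number here means a stronger inhibitor of growth, a higher number a weaker inhibitor of growth), compound 1 gives 87200 nM. For compound 2 this assay reports only a limit, > 100000 nM, which is the limit of > 100000 nM in this assay, at which 1 of the 2 values shown sits. Compound 3 `CCCCC[Se]c1nc(N)c2cccnc2n1` has not yet been measured in this assay. The change from compound 2 to compound 3 is one nitrogen atom in place of a group of 6 heavy atoms (5 carbon, 1 selenium; no ring), on an aromatic carbon. Because compound 1 also carries an amino group and gives 87200 nM, compound 3 is expected to sit in the same region. Compound 3 is estimated at 80000 nM, between 35000 nM and 180000 nM, a step of an at least 1.2-fold lower number from compound 2 to compound 3 (0.09 log units; that floor lies within the scatter) expected to stay within the usual scatter.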

Compound 3, concentration for total growth inhibition: 40200 nM
Estimate against measurement, compound 3: 2.0-fold (0.30 log units) above; the range from low to high includes it.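

In this assay, the amino group in place of the group of 6 heavy atoms on this aromatic carbon gives an at least 2.4-fold lower number from compound 2 to compound 3 (0.39 log units; beyond the scatter). That step is only a floor, since the value of compound 2 is a limit: the limit of > 100000 nM in this assay, at which 1 of the 3 values shown sits.

With the amino group in place, the chain on selenium also matters: butyl in place of hydrogen on the chain carbon bound to selenium gives a 2.2-fold lower number from compound 1 to compound 3 (0.34 log units; beyond the scatter). The compounds shown leave open how a methylamino group or a hydroxyl on this aromatic carbon would read in this assay, and whether a still longer chain on selenium would continue this step.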